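The source may hold more compounds than are shown below. What is called first, only, known or untested is meant among the compounds shown, and "the series" means these compounds.

Compound 1 `NC(=O)c1c(NC(=O)c2ccccc2Cl)sc2c1CCN(Cc1ccc(Cl)cc1Cl)C2` has the lowest number of the three measured compounds in a functional assay on HL-60 cells (Homo sapiens) for antiproliferative activity, with a stated time of 24 h; on this read-out higher numbers stand for weaker inhibition and lower numbers for stronger inhibition; compound 1 gives 8010 nM. Compound 3 `NC(=O)c1c(NC(=O)c2ccccc2F)sc2c1CCN(Cc1ccc(Cl)cc1Cl)C2` gives 13100 nM, and compound 2 `Cc1ccc(C(=O)Nc2sc3c(c2C(N)=O)CCN(Cc2ccc(Cl)cc2Cl)C3)cc1` gives 19900 nM. The step of a 1.6-fold higher number from compound 1 to compound 3 (0.21 log units; within the scatter) lies within the scatter, whereas a 2.5-fold higher number from compound 1 to compound 2 (0.40 log units; beyond the scatter) is modest and beyond it. Compound 4 `NC(=O)c1c(NC(=O)c2ccccc2Cl)sc2c1CCN(C(=S)Nc1c(Cl)cccc1Cl)C2` differs from compound 1 in one place: a group of 11 heavy atoms (7 carbon, 1 nitrogen, 1 sulfur, 2 chlorine; one six-membered aromatic ring of carbon only) in place of a group of 9 heavy atoms (7 carbon, 2 chlorine; one six-membered aromatic ring of carbon only), on an amine nitrogen in a ring. Among the compounds with values here, none of the measured steps touches this part of the shared core; all three alter the group on the carbonyl carbon, and even the largest of them, a 2.5-fold higher number from compound 1 to compound 2 (0.40 log units; beyond the scatter), was modest. With no direct guide, a step of a 1.1-fold higher number from compound 1 to compound 4 (0.05 log units; within the scatter) is expected, meaning no change beyond the scatter. Compound 4 is therefore estimated at 9000 nM, with a range from 2500 nM to 35000 nM.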

Compound 4, half-maximal inhibitory concentration: 3950 nM
Estimate against measurement, compound 4: 2.3-fold (0.36 log units) above; low and high end bracket the measured number.
By their numbers in this assay, from the lowest: compound 4; then compounds 1, 3 and 2 (each within the scatter of the next, the first and the last beyond it).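

Within the data shown here, replacing the 2,4-dichlorobenzyl on the amine nitrogen in a ring gives a 2.0-fold lower number from compound 1 to compound 4 (0.31 log units; beyond the scatter), so in this assay this position, which no earlier step touched, can take a different group without loss. That step is modest, yet it is beyond the scatter, and the new group brings a sulfur, a nitrogen, a double bond outside aromatic rings and a hydrogen-bond donor all at once. Nothing available explains the shift. Which of these features matters stays open, as the compounds shown do not separate them. A plain benzyl, an acetyl or a urea with oxygen in place of sulfur on this nitrogen could help to tell them apart.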